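Changing the Aryl Group of Compound 1 at One Position

The source may report more compounds than this note shows. Statements on the series, on what has been measured and on what is new or still open speak of the compounds shown alone.

Compound 1 `N#Cc1ccc(/C=N/NC(=O)Nc2cc3c(Nc4ccc(F)c(Cl)c4)ncnc3cc2O[C@H]2CCOC2)cc1`: "not determined" (no result reported)
Compound 2 `COc1ccc(/C=N/NC(=O)Nc2cc3c(Nc4ccc(F)c(Cl)c4)ncnc3cc2O[C@H]2CCOC2)c(OC)c1OC`: 33800 nM
Compound 3 `O=C(N/N=C/c1ccc(O)c(Br)c1)Nc1cc2c(Nc3ccc(F)c(Cl)c3)ncnc2cc1O[C@H]1CCOC1`: 2690 nM
Compound 4 `CCN(CC)c1ccc(/C=N/NC(=O)Nc2cc3c(Nc4ccc(F)c(Cl)c4)ncnc3cc2O[C@H]2CCOC2)c(O)c1`: not yet measured

In a functional assay on MCF7 cells (Homo sapiens) for cytotoxicity, read by MTT assay, with a stated time of 72 h (a lower number here means a stronger inhibitor, a higher number a weaker inhibitor), compound 1 stands without a number, so its own activity gives no anchor. The change from compound 1 to compound 4 is 4-(diethylamino)-2-hydroxyphenyl in place of 4-cyanophenyl on a carbon with a double bond to nitrogen. Within the data shown here, only one measured step touches the same position: a 13-fold lower number from compound 2 to compound 3 (1.10 log units; beyond the scatter). Among the measured compounds shown here, that step shows that exchanging the aryl group on the carbon with a double bond to nitrogen can move the result well beyond the scatter, but with only two measured compounds at this position no direction can be read for an entering group that matches neither of them. Compound 4 carries a hydroxyl on its entering ring, as compound 3 does, and compound 3 is the stronger of the two measured compounds, so the expectation leans toward a number nearer to compound 3 than to compound 2, while leaving a wide range for the uncertainty. Compound 4 is therefore estimated in this assay at 3500 nM, with a range from 800 nM to 15000 nM.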

Compound 4, half-maximal inhibitory concentration: 15600 nM
The estimate for compound 4 lay 4.5-fold (0.65 log units) below the measured number; the whole stated range lies below it.
By their numbers in this assay, from the lowest: compound 3; then compound 4; then compound 2.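

In this assay, sharing a hydroxyl on the aryl ring did not bring compound 4 level with compound 3: placing 4-(diethylamino)-2-hydroxyphenyl on the carbon with a double bond to nitrogen in place of 3-bromo-4-hydroxyphenyl gives a 5.8-fold higher number from compound 3 to compound 4 (0.76 log units; beyond the scatter). Against 2,3,4-trimethoxyphenyl the same group gives a 2.2-fold lower number from compound 2 to compound 4 (0.34 log units; beyond the scatter), which is a smaller move than a 13-fold lower number from compound 2 to compound 3 (1.10 log units; beyond the scatter), so the three measured aryl groups now form an order in which the two hydroxyl-bearing rings still differ clearly from each other. Nothing shown gives a reason for this order.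

Among these compounds, compound 1 has no number, so no step from it can be read, and it remains open where 4-cyanophenyl stands against these three aryl groups. Also open, as far as these compounds go, is how a plain phenyl, a 4-hydroxyphenyl without the bromine, a 4-(diethylamino)phenyl without the hydroxyl, or a ring bearing a carboxylic acid would compare at this position, and so which part of each group goes with its number.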